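The source may report more compounds than this note shows. Statements on the series, on what has been measured and on what is new or still open speak of the compounds shown alone.

Working notes on the sulfonamide series.

Of the compounds shown here, three carry numbers so far. Compound 1 `O=S(=O)(NCCCCNCc1ccc(Br)cc1)c1cc(C(F)(F)F)cc(C(F)(F)F)c1` gives 1600 nM in a functional assay on HT-29 cells (Homo sapiens) for inhibition, read by MTT assay, with a stated time of 72 h; on this read-out higher numbers stand for weaker inhibition of growth and lower numbers for stronger inhibition of growth. Compound 2 `COc1ccc(CNCCCNS(=O)(=O)c2cc(C(F)(F)F)cc(C(F)(F)F)c2)cc1OC` gives 2700 nM in this assay, and compound 3 `O=S(=O)(NCCCNCc1cccc2ccccc12)c1cc(C(F)(F)F)cc(C(F)(F)F)c1` gives 2600 nM. Compound 1 holds the lowest of the three numbers, but its gaps to compound 3 and to compound 2 are both within the scatter, so no order among the three can be read from these values.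

Among the compounds with values here, the one step measured between compounds differing in a single place is a 1.0-fold lower number from compound 2 to compound 3 (0.02 log units; within the scatter); the aryl change on the saturated chain carbon bound to the amine nitrogen left the number essentially where it was.

Compound 4 `O=S(=O)(NCCCNCc1cccc(Cl)c1)c1cc(C(F)(F)F)cc(C(F)(F)F)c1` remains to be measured. Relative to compound 1 the change is (3-chlorobenzyl)amino in place of ((4-bromobenzyl)amino)methyl on a saturated chain carbon, three bonds along the chain from a sulfonamide nitrogen. This touches both the aryl group and the length of the chain between the two nitrogens; compound 2 and compound 3 share the shorter chain of compound 4 and sit in a narrow band with each other. Within the data shown here, no measured step isolates the chain length, so the expectation rests on the whole set: compound 4 is expected near the values of compound 2 and compound 3, a step of a 1.5-fold higher number from compound 1 to compound 4 (0.18 log units; within the scatter) that is expected to stay within the scatter. The estimate for compound 4 is 2400 nM, with a range from 1100 nM to 5200 nM.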

Compound 4, concentration for 50% growth inhibition: 14000 nM
Beside the measured number, compound 4's estimate is 5.8-fold (0.77 log units) below it; the measured number lies above the stated range.
By their numbers in this assay, from the lowest: compounds 1, 3 and 2 (each within the scatter of the next); then compound 4.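

In this assay the aryl group on the saturated chain carbon bound to an amine nitrogen now shows an effect that the earlier pair did not: 3-chlorophenyl in place of naphthalen-1-yl gives a 5.4-fold higher number from compound 3 to compound 4 (0.73 log units; beyond the scatter) and 3-chlorophenyl in place of 3,4-dimethoxyphenyl gives a 5.2-fold higher number from compound 2 to compound 4 (0.71 log units; beyond the scatter), while naphthalen-1-yl and 3,4-dimethoxyphenyl stay within the scatter of each other. The larger replacement, (3-chlorobenzyl)amino in place of ((4-bromobenzyl)amino)methyl, gives an 8.8-fold higher number from compound 1 to compound 4 (0.94 log units; beyond the scatter), but it alters the aryl group and the chain together, so this step cannot assign the loss to either one alone. Nothing available explains why compound 4 stands apart from the other three compounds.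

The compounds shown leave open whether the 3-chlorophenyl group itself accounts for the higher number, or whether an unsubstituted phenyl or a 4-chlorophenyl on the same carbon would give a similar value. A 4-bromophenyl on the chain of compound 4 would separate the aryl change from the chain change, and a longer chain carrying 3-chlorophenyl would test the same question from the other side.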